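The compounds below may be only part of what the source reports. "The series", "measured", "known", "first", "only" and "open" are said of these compounds alone.

Measured to date in an in vitro assay on BTI-TN-5B1-4 cells for inhibition of Amine oxidase [flavin-containing] B (Homo sapiens), read by fluorescence; a lower number here means a stronger inhibitor, a higher number a weaker inhibitor:
compound 1, `CC(C)CNC(=O)c1cc2ccccc2oc1=O`, 3270 nM;
compound 2, `Cc1cccc(NC(=O)c2cc3ccccc3oc2=O)c1`, 600 nM;
compound 3, `Cc1ccc(NC(=O)c2cc3ccccc3oc2=O)cc1`, 710 nM.

Compound 3 stands second highest of the three numbers; its gap to compound 2 is within the scatter, while compound 1 sits well apart, a 4.6-fold lower number from compound 1 to compound 3 (0.66 log units; beyond the scatter). Compound 4, `Cc1ccc(NC(=O)c2cc3ccccc3oc2=O)c(C)c1`, differs from compound 3 by methyl in place of hydrogen on an aromatic carbon. The step bearing most directly on this is a 1.2-fold higher number from compound 2 to compound 3 (0.07 log units; within the scatter), which shows that moving a single methyl around the ring left the number essentially unchanged. The larger steps of a 5.5-fold lower number from compound 1 to compound 2 (0.74 log units; beyond the scatter) and a 4.6-fold lower number from compound 1 to compound 3 (0.66 log units; beyond the scatter) concern the aryl-for-isobutyl swap and do not apply here. A second methyl is therefore expected to give at most a step within the scatter, a 1.1-fold lower number from compound 3 to compound 4 (0.06 log units; within the scatter). Compound 4 is estimated at 620 nM, range 310 nM to 1250 nM.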

Compound 4, half-maximal inhibitory concentration: 13700 nM
Compound 4: the middle estimate sits 22-fold (1.34 log units) below what was measured; the whole stated range lies below it.
By their numbers in this assay, from the lowest: compounds 2 and 3 (each within the scatter of the next); then compound 1; then compound 4.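

Methyl in place of hydrogen on an aromatic carbon, ortho to a large group, gives a 19-fold higher number from compound 3 to compound 4 (1.29 log units; beyond the scatter) and is a large loss. Moving the methyl in a 1.2-fold higher number from compound 2 to compound 3 (0.07 log units; within the scatter) showed no such sensitivity, so this ortho position responds far more strongly to substitution than that earlier change suggested. No measurement among these data accounts for the loss.

Still open, going by these compounds, is whether fluorine or methoxy at this position would be tolerated. On these data alone, it is also open whether the ortho methyl would have the same effect without the methyl group meta to it.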